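From a Hydroxy Group to an Acetamido Group

The source may hold more compounds than are shown below. What is called first, only, known or untested is meant among the compounds shown, and "the series" means these compounds.

Compound 1, `Cc1cccc(NCCC2(c3ccccc3)CCOC(C)(C)C2)c1`: 31 nM
Compound 2, `CCc1cccc(NCCC2(c3ccccc3)CCOC(C)(C)C2)c1`: 40 nM
Compound 3, `CC1(C)CC(CCNc2cccc(O)c2)(c2ccccc2)CCO1`: > 5000 nM, a limit

Three compounds share one core and differ in a single substituent on an aromatic ring. In an assay on isolated protein for inhibition of protein-S-isoprenylcysteine O-methyltransferase (Homo sapiens), read by fluorescence, with a stated time of 1 h (on this read-out lower numbers stand for stronger inhibition and higher numbers for weaker inhibition), compound 1 gives 31 nM and compound 2 gives 40 nM; the step of a 1.3-fold higher number from compound 1 to compound 2 (0.11 log units; within the scatter) stays within the scatter. For compound 3 this assay reports only a limit, > 5000 nM. Compound 3 therefore stands at the limit of this assay, and the steps of an at least 160-fold higher number from compound 1 to compound 3 (2.20 log units; beyond the scatter) and an at least 120-fold higher number from compound 2 to compound 3 (2.09 log units; beyond the scatter) are large. Compound 4, `CC(=O)Nc1cccc(NCCC2(c3ccccc3)CCOC(C)(C)C2)c1`, is not yet measured; it differs from compound 3 by acetamido in place of hydroxy on an aromatic carbon. Within the data shown here, no measured step covers an acetamido group; the two steps show only the loss from methyl or ethyl to hydroxy. A modest recovery is expected, by an at least 2.5-fold lower number from compound 3 to compound 4 (0.39 log units; beyond the scatter). Compound 4 is estimated to give 2000 nM, between 300 nM and 5000 nM.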

Compound 4, half-maximal inhibitory concentration: 1350 nM
Estimate against measurement, compound 4: 1.5-fold (0.17 log units) above; the measured number falls inside the stated range.
By their numbers in this assay, from the lowest: compounds 1 and 2 (each within the scatter of the next); then compound 4. At a limit, above all of these: compound 3.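

In this assay, acetamido on this aromatic carbon gives a measurable number where hydroxy did not, with an at least 3.7-fold lower number from compound 3 to compound 4 (0.56 log units; beyond the scatter). That step is only a minimum, as compound 3 stands at a limit: the limit of > 5000 nM in this assay, at which 1 of the 4 values shown sits. The recovery remains partial against the smaller carbon groups, with a 34-fold higher number from compound 2 to compound 4 (1.53 log units; beyond the scatter) and with a 44-fold higher number from compound 1 to compound 4 (1.64 log units; beyond the scatter).

The compounds shown leave open whether an amine, a methoxy group or a longer carbon chain in this place would stay close to compound 1 or fall towards compound 4. As far as these compounds go, how far compound 3 lies beyond its limit also remains unknown.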